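Trading naphthalen-2-yl for 4-methylphenyl on a shared core

This account rests on a few compounds, and the source may have more. Where it says the series, first, only, none or still open, it means among the compounds named here.

In a functional assay on Jurkat cells (Homo sapiens) for antiproliferative activity, read by MTT assay, with a stated time of 72 h (a higher number here means a weaker inhibitor, a lower number a stronger inhibitor), compound 1 (`CNc1nc(-c2cc(OC)c(OC)c(OC)c2)c(-c2ccc(C)cc2)s1`) gives 19 nM and compound 2 (`COc1cc(-c2nc(N(C)C)sc2-c2ccc3ccccc3c2)cc(OC)c1OC`) gives 836 nM as the higher of the two numbers, a gap well beyond the usual scatter of repeat measurements. Compound 2 is therefore the weaker inhibitor of this pair.

The next structure is compound 3 (`COc1cc(-c2nc(N(C)C)sc2-c2ccc(C)cc2)cc(OC)c1OC`), in which 4-methylphenyl takes the place of naphthalen-2-yl on an aromatic carbon (4-methylphenyl in place of naphthalen-2-yl on an aromatic carbon). Among the measured compounds shown here, no measured pair shows this swap on its own, so its size has to be judged indirectly. Compound 3 shares its 4-methylphenyl group with compound 1 at 19 nM and its dimethylamino group with compound 2 at 836 nM so a number between these two seems the most reasonable expectation. The expected change in this assay is a 5.6-fold lower number from compound 2 to compound 3 (0.75 log units; beyond the scatter) toward a stronger inhibitor and beyond the scatter. For compound 3 the estimated value is 150 nM with an expected range from 35 nM to 650 nM as a working guess.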

Compound 3, half-maximal inhibitory concentration: 6660 nM
Beside the measured number, compound 3's estimate is 44-fold (1.65 log units) below it; measured number outside the range, above it.
By their numbers in this assay, from the lowest: compound 1; then compound 2; then compound 3.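

In this assay, the swap at this aromatic carbon next to the ring sulfur has a clear direction on the dimethylamino core: an 8.0-fold higher number from compound 2 to compound 3 (0.90 log units; beyond the scatter) shows that 4-methylphenyl gives a weaker inhibitor than naphthalen-2-yl in this pair. Among the compounds shown here, compound 3 also gives the first direct look at the ring nitrogen substituent, where a 350-fold higher number from compound 1 to compound 3 (2.54 log units; beyond the scatter) follows from adding one methyl in place of the hydrogen on that nitrogen, a large loss set against the modest step at the aromatic carbon. Among these compounds, then, the single methyl on the nitrogen moves the number much further than the exchange of the two aromatic groups, and no measurement given here explains either step.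

It remains open whether naphthalen-2-yl would still outperform 4-methylphenyl with only one methyl on the nitrogen, since that swap is shown only alongside the dimethylamino group. The compounds shown also leave open how an unsubstituted amino group or a longer chain such as ethyl on that nitrogen would compare, and how a 4-chlorophenyl group would fare at the aromatic carbon.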